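Swapping the bicyclic amine for a dimethylaminoethyl chain

The compounds below may be only part of what the source reports. "The series", "measured", "known", "first", "only" and "open" are said of these compounds alone.

Three compounds have been measured in an assay on HEK293 cells for displacement of a labelled ligand from B1 bradykinin receptor (Homo sapiens), read by scintillation counting; a lower number here means a stronger inhibitor, a higher number a weaker inhibitor:
compound 1 `COc1cc(C)c(S(=O)(=O)N(C)CCOCC(=O)N2CCN(CCCN(C)C)CC2)c(C)c1` gives 5.8 nM;
compound 2 `COc1cc(C)c(S(=O)(=O)N(C)CCOCC(=O)N2CCN([C@H]3CN4CCC3CC4)CC2)c(C)c1` gives 34 nM;
compound 3 `CN(Cc1ccc(C2=NCCN2)cc1)C(=O)COCCN(C)S(=O)(=O)c1ccccc1C(F)(F)F` gives 2.8 nM.

Compound 2 stands highest of these three numbers; compound 1 lies nearest and compound 3 furthest, both gaps beyond the scatter. Compound 4 `COc1cc(C)c(S(=O)(=O)N(C)CCOCC(=O)N2CCN(CCN(C)C)CC2)c(C)c1` differs from compound 2 in one place: a group of 5 heavy atoms (4 carbon, 1 nitrogen; no ring) in place of a group of 8 heavy atoms (7 carbon, 1 nitrogen; 2 six-membered non-aromatic rings with 1 hetero atom each), on an amine nitrogen in a ring. For the measured compounds named here, the one measured step that bears on this change is a 5.9-fold higher number from compound 1 to compound 2 (0.77 log units; beyond the scatter), where the same amine nitrogen went from an acyclic chain to the bicyclic group. Going by the values given here, compound 4 returns to an acyclic chain, though not the same chain as in compound 1, and no measured step covers that remaining difference. Compound 4 is therefore expected to give about 8 nM, within a range of 3 nM to 25 nM. That estimate means an expected downward step of a 4.3-fold lower number from compound 2 to compound 4 (0.63 log units; beyond the scatter), beyond the scatter.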

Compound 4, inhibition constant: 106 nM
Compound 4: the middle estimate sits 13-fold (1.12 log units) below what was measured; measured number outside the range, above it.
By their numbers in this assay, from the lowest: compound 3; then compound 1; then compound 2; then compound 4.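

In this assay, the step of an 18-fold higher number from compound 1 to compound 4 (1.26 log units; beyond the scatter) comes with dimethylamino in place of (dimethylamino)methyl, so this position responds strongly to a small change in the chain. The step of a 3.1-fold higher number from compound 2 to compound 4 (0.49 log units; beyond the scatter) shows that an acyclic chain does not in itself give a lower number, as the bicyclic group of compound 2 falls in order between the two chains. Nothing at hand explains the gap between these chains. On these data alone, whether a longer chain ending in dimethylamino would lower the number further remains open, as does the effect of a primary amine at the chain end.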